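Methoxy in place of methyl on a weak inhibitor

The compounds below may be only part of what the source reports. "The series", "measured", "known", "first", "only" and "open" are said of these compounds alone.

- compound 1 `O=[N+]([O-])c1ccc(Nc2nnc(-c3c[nH]c4ccccc34)o2)cc1`: 45000 nM
- compound 2 `Cc1ccc(Nc2nnc(-c3c[nH]c4ccccc34)o2)cc1`: > 100000 nM (a limit)
- compound 3 `COc1ccc(Nc2nnc(-c3c[nH]c4ccccc34)o2)cc1`: not yet measured

In a functional assay on Jurkat cells (Homo sapiens) for inhibition, with a stated time of 24 h (a lower number here means a stronger inhibitor, a higher number a weaker inhibitor), compound 2 gives > 100000 nM, which is a limit and not a number. Compound 3 carries methoxy in place of methyl on an aromatic carbon. Going by the values given here, the only measured step at this place is an at least 2.2-fold higher number from compound 1 to compound 2 (0.34 log units; beyond the scatter), with methyl in place of nitro. It does not involve methoxy, so it sets no firm size, and no step beyond the scatter is expected. The expected change is an at least 1.1-fold lower number from compound 2 to compound 3 (0.04 log units; that floor lies within the scatter). Compound 3 is estimated at 90000 nM, within an expected range of 35000 nM to 200000 nM.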

Compound 3, half-maximal inhibitory concentration: > 100000 nM
Compound 3 ended at the assay's limit; the forecaster's own chance of this, stated with the estimate: 55%; middle value at least 1.1-fold (0.04 log units) from the limit.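

Methoxy in place of nitro on this aromatic carbon gives an at least 2.2-fold higher number from compound 1 to compound 3 (0.34 log units; beyond the scatter) in this assay, so a second replacement of nitro, after methyl, also ends without a measurable value. Compound 3 gives > 100000 nM, which is a limit and not a number. The step between compound 2 and compound 3 cannot be read, as both compounds end at the same limit: the limit of > 100000 nM in this assay, at which 2 of the 3 values shown sit.

As far as these compounds go, how far methoxy and methyl differ here stays open. So does how an amine or a carboxylic acid on this carbon would compare with nitro in this assay.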